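The source may hold more compounds than are shown below. What is called first, only, known or untested is meant among the compounds shown, and "the series" means these compounds.

Measured in a physicochemical assay for acid dissociation:
- compound 1 `CC(C)CN1C(=O)CN(Cc2ccc(-c3ccc(F)c(CN4CCCC(C)C4)n3)cc2)C1=O`: 8.4
- compound 2 `O=C1CN(Cc2ccc(-c3ccc(F)c(CN4CCCCC4)n3)cc2)C(=O)N1CC1CC1`: 8.5

Compound 2, at 8.5, lies within the scatter of compound 1, at 8.4, so the two numbers do not separate the pair. The next compound to be measured is compound 3 `CC(C)CN1C(=O)CN(Cc2ccc(-c3ccc(F)c(CN4CCCCC4)n3)cc2)C1=O`. It differs from compound 2 by isopropyl in place of cyclopropyl on a saturated chain carbon bound to an amide-type nitrogen in a ring, which, cut one bond further out, reads cyclopropylmethyl to isobutyl. Within the data shown here, no two measured compounds differ in one place only, so the data offer no direct step for this change. In this assay, no step beyond the scatter is expected, in either direction. The expected step of no change at the digits printed from compound 2 to compound 3 (within the scatter) is therefore estimated as small. For compound 3 the estimated value is 8.5, with an expected range of 8.2 to 8.8.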

Compound 3, acid dissociation constant: 8.6
For compound 3 the middle estimate is 0.10 log units below the measured one, and the stated range covers the measured number.
By their numbers in this assay, from the lowest: compounds 1, 2 and 3 (each within the scatter of the next).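

In this assay, isopropyl in place of cyclopropyl on a saturated chain carbon bound to an amide-type nitrogen in a ring gives a number 0.10 log units higher from compound 2 to compound 3 (within the scatter), so this first single-place comparison at that position does not separate the open group from the three-membered ring. Hydrogen in place of methyl on a saturated ring carbon gives a number 0.20 log units higher from compound 1 to compound 3 (within the scatter), so that second single-place comparison does not separate the pair either. Nothing available bears on a cause for either step.

Among these compounds, each position is covered by only one pair, so neither comparison indicates how far the reading tolerates other groups. From the compounds shown here alone, it remains open whether a longer chain or a chain ending in an amine at the first position, or ethyl in place of methyl on the saturated ring carbon, would also stay within the scatter.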